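Ethyl in place of 4-methoxyphenyl: a question of tolerance

The source may report more compounds than this note shows. Statements on the series, on what has been measured and on what is new or still open speak of the compounds shown alone.

In a toxicity assay on HEK-293T cells (Homo sapiens) for inhibition, read by MTT assay, with a stated time of 24 h (a higher number here means that more compound is tolerated, a lower number that less compound is tolerated), compound 3 `COc1ccc(N2CCN(c3c(CO)c(=O)oc4ccccc34)CC2)cc1` gives > 50000 nM as a limit and not a number. Compound 1 `O=c1oc2ccccc2c(N2CCN(c3cccc(Cl)c3Cl)CC2)c1CO` gives > 50000 nM as a limit too. Compound 2 `O=c1oc2ccccc2c(N2CCN(c3ccccc3)CC2)c1CO` also gives > 50000 nM as a limit. The whole record so far is therefore the limit of > 50000 nM in this assay, at which 3 of the 3 values shown sit, and nothing finer.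

Compound 4 `CCN1CCN(c2c(CO)c(=O)oc3ccccc23)CC1` has not yet been measured. It carries ethyl in place of 4-methoxyphenyl on an amine nitrogen in a ring and so gives up its aromatic ring at that nitrogen.

Three measured changes to the group on that nitrogen bear on this one. They are a step that the two limits leave unreadable from compound 1 to compound 2 and a step that the two limits leave unreadable from compound 1 to compound 3 and a step that the two limits leave unreadable from compound 2 to compound 3 so none offers a size to carry over. All three compounds keep an aromatic ring there, which makes the new change a larger one than any tested so far.

The expectation rests on compound 3 at > 50000 nM as a limit. No step beyond the scatter is expected in this assay in either direction, although the data cannot exclude one. The expected step is a number no higher from compound 3 to compound 4 (the limit leaves the size open) on this reading. Compound 4 is estimated at 50000 nM with an expected range from 20000 nM to 100000 nM if a number is reported at all.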

Compound 4, half-maximal cytotoxic concentration: > 50000 nM
Compound 4: a limit, no number; the forecaster's own chance of this, stated with the estimate: 85%; the middle value lies on the limit itself.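

Compound 4 also gives a limit and not a number in this assay, so no step from compound 1, compound 2 or compound 3 to compound 4 can be read, and all four compounds now stand at the same limit: the limit of > 50000 nM in this assay, at which 4 of the 4 values shown sit.

The compounds shown leave open at what concentration any of them becomes toxic to these cells, and whether the group on the amine nitrogen in the ring affects that concentration.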